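Dimethylamino on the chain carbon: a small expected step

The source may report more compounds than this note shows. Statements on the series, on what has been measured and on what is new or still open speak of the compounds shown alone.

In a functional assay on the whole organism with Mus musculus as the target, in the rotarod test (on this read-out lower numbers stand for an effect already at smaller amounts and higher numbers for an effect only at larger amounts of compound), compound 3 (`CN(C(=O)CNC(=O)CN1CCN(c2ccccc2)CC1)c1ccc(Cl)cc1C(=O)c1ccccc1Cl`) gives > 100 mg/kg, which is a limit and not a number. Compound 1 (`CN1CCN(CC(=O)NCC(=O)N(C)c2ccc(Cl)cc2C(=O)c2ccccc2Cl)CC1`) gives > 100 mg/kg, also a limit. Compound 2 (`CCCC(=O)NCC(=O)N(C)c1ccc(Cl)cc1C(=O)c1ccccc1Cl`) gives a number, 55.2 mg/kg. Compound 4 (`CN(C)CC(=O)NCC(=O)N(C)c1ccc(Cl)cc1C(=O)c1ccccc1Cl`) differs from the third of these at one place: dimethylamino in place of 4-phenylpiperazin-1-yl on a saturated chain carbon bound to a carbonyl carbon. Two measured steps alter that same place: an at least 1.8-fold lower number from compound 1 to compound 2 (0.25 log units; that floor lies within the scatter) and an at least 1.8-fold higher number from compound 2 to compound 3 (0.25 log units; that floor lies within the scatter). Both are floors within the scatter, so neither fixes a size. A modest move towards a lower number is expected, and another limit remains possible. The expected change is an at least 1.2-fold lower number from compound 3 to compound 4 (0.09 log units; that floor lies within the scatter). For compound 4 the estimate is 80 mg/kg, with an expected range of 35 mg/kg to 180 mg/kg.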

Compound 4, dose for half-maximal effect: 26 mg/kg
Compound 4: the middle estimate sits 3.1-fold (0.49 log units) above what was measured, outside the stated range (below it).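

Dimethylamino gives the first step of exact size at this place on the saturated chain carbon bound to a carbonyl carbon in this assay, with a 2.1-fold lower number from compound 2 to compound 4 (0.33 log units; beyond the scatter). Against the two piperazine compounds the steps also clear the scatter, with an at least 3.8-fold lower number from compound 3 to compound 4 (0.58 log units; beyond the scatter) and an at least 3.8-fold lower number from compound 1 to compound 4 (0.58 log units; beyond the scatter). Both are floors, since each starts from a limit: the limit of > 100 mg/kg in this assay, at which 2 of the 4 values shown sit.

Open, going by these compounds, is whether diethylamino, pyrrolidin-1-yl or morpholin-4-yl at this place would hold or lower the number. Also open, on these data alone, is whether an unsubstituted piperazin-1-yl would stay at a limit.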